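The source may report more compounds than this note shows. Statements on the series, on what has been measured and on what is new or still open speak of the compounds shown alone.

Measured so far:
compound 1, `Cc1c(CCCC(=O)O)c2cccc(/C=C/c3ccc(OCCCCc4c(F)c(F)cc(F)c4F)cc3)c2n1CC(=O)O`: 0.5 10^-6 cm/s
compound 2, `Cc1c(Cl)cccc1CCCCOc1ccc(C#Cc2cccc3c(CCC(=O)O)c(C)n(CCCCC(=O)O)c23)cc1`: 4.6 10^-6 cm/s
compound 3, `Cc1c(Cl)cccc1CCCCOc1ccc(C#Cc2cccc3c(CC(=O)O)c(C)n(CCCC(=O)O)c23)cc1`: 4.4 10^-6 cm/s

All three were tested in a physicochemical assay for permeability, using PAMPA, with a stated time of 4 h, at pH 7.4, tested at 50 uM; on this read-out lower numbers stand for lower permeability and higher numbers for higher permeability. Compound 1 gives 0.5 10^-6 cm/s, the lowest of the three numbers; its gaps to compound 3 and to compound 2 both lie beyond the scatter, compound 3 being the nearer of the two. Compound 4, `Cc1c(CCCC(=O)O)c2cccc(/C=C/c3ccc(OCCCCc4c(F)ccc(F)c4F)cc3)c2n1CC(=O)O`, is not yet measured. It differs from compound 1 in one place: hydrogen in place of fluoro on an aromatic carbon. Among the measured compounds shown here, no pair of measured compounds shares this single change, so no measured step guides the expectation. The step in this assay is expected to be small, if anything slightly downward, and within the scatter. For compound 4 the expected step is a 1.3-fold lower number from compound 1 to compound 4 (0.10 log units; within the scatter), giving an estimate of 0.4 10^-6 cm/s, with a range from 0.2 10^-6 cm/s to 0.9 10^-6 cm/s.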

Compound 4, apparent permeability: 2.6 10^-6 cm/s
Compound 4: middle estimate off by 6.5-fold (0.81 log units), on the low side, and the stated range ends below it.
By their numbers in this assay, from the lowest: compound 1; then compounds 4, 3 and 2 (each within the scatter of the next).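

Replacing the 2,3,5,6-tetrafluorophenyl group with 2,3,6-trifluorophenyl gives, in this assay, a 5.2-fold higher number from compound 1 to compound 4 (0.72 log units; beyond the scatter), the only single-place step among these compounds. This aromatic carbon, para to a fluoro group and meta to a large group, therefore matters on this read-out: losing this one fluoro moves the number beyond the scatter. Nothing measured here explains the rise. From the compounds shown here alone, whether removing any of the other fluoro groups on this ring has a similar effect remains open, as does the outcome with a methoxy group or a nitrile on this carbon.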